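The compounds below may be only part of what the source reports. "The series", "measured", "known", "first", "only" and "open" are said of these compounds alone.

Compound 2 `CCC1=C(O)c2c(oc(-c3ccccc3)cc2=O)C(CC)(CC)C1=O` in a functional assay on MCF7 cells (Homo sapiens) for cytotoxicity, read by sulforhodamine B assay (a lower number here means that less compound is needed, a higher number that more compound is needed for the effect), returns only a limit, > 20 ug/mL. Compound 1 `CC1=C(O)C(C)(C)c2oc(-c3ccccc3)cc(=O)c2C1=O` likewise gives a limit in this assay, > 20 ug/mL. Going by the values given here, both results sit at the limit of > 20 ug/mL in this assay, at which 2 of the 2 values shown sit, so the measured pair shows no step at all. Compound 3 `CCC1=C(O)c2c(oc(-c3ccc(C)cc3)cc2=O)C(CC)(CC)C1=O` differs from compound 2 by methyl in place of hydrogen on an aromatic carbon. For such a change no step beyond the scatter is expected in this assay. The potency of compound 3 is therefore estimated at 30 ug/mL, in the range 12 ug/mL to 80 ug/mL, probably again reported as a limit. The expected step is a step that the limit leaves unreadable from compound 2 to compound 3.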

Compound 3, concentration for half-maximal effect: > 20 ug/mL
Compound 3: only a limit was reported; the forecaster's own chance of this, stated with the estimate: 75%; the middle value is on the limit's open side.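

Compound 3 returns a limit, as compound 2 does, so no step can be read between them: the limit of > 20 ug/mL in this assay, at which 3 of the 3 values shown sit.

The compounds shown leave open whether any change on the shared core gives a readable value in this assay.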